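The compounds below may be only part of what the source reports. "The series", "measured", "known", "first", "only" and "open" are said of these compounds alone.

Measured compounds: compound 1 `COC(=O)c1cc(=O)c2c(OC)cc(OC)cc2n1C`; compound 2 `COc1ccc(-c2cc(=O)c3c(OC)cc(OC)cc3n2S(=O)(=O)c2ccc(C)c([N+](=O)[O-])c2)cc1`; compound 3 `COc1ccc(-c2cc(=O)c3c(OC)cc(OC)cc3n2S(=O)(=O)c2c(C(C)C)cc(C(C)C)cc2C(C)C)cc1`.

In a functional assay on HepG2 cells (Homo sapiens) for antiproliferative activity, with a stated time of 72 h (on this read-out higher numbers stand for an effect only at larger amounts of compound and lower numbers for an effect already at smaller amounts), compound 1 reaches only the limit > 19000 nM. Compound 2 likewise gives only the limit > 51700 nM in this assay. Compound 3 gives the limit > 341000 nM in this assay. Going by the values given here, compound 2 thus stands at a limit, as do the other two, and no measured step between any pair of them exists to order them.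

Compound 4 `COc1ccc(-c2cc(=O)c3c(OC)cc(OC)cc3n2S(=O)(=O)Cc2ccccc2)cc1` differs from compound 2 by benzyl in place of 4-methyl-3-nitrophenyl on a sulfonyl sulfur. Among the compounds with values here, with no measured step anywhere in this set, no shift beyond the scatter is expected in this assay; the expected step that the limit leaves unreadable from compound 2 to compound 4 is essentially none. Compound 4 is therefore estimated at 60000 nM, within 10000 nM to 300000 nM, and is most likely to be reported again only as a limit.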

Compound 4, half-maximal effective concentration: > 34400 nM
Compound 4 was reported as a limit; the forecaster's own chance of this, stated with the estimate: 85%; the middle value does not contradict the limit.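

Compound 4 gives only a limit, > 34400 nM, in this assay. Going by these compounds alone, compound 2 also gives only a limit, > 51700 nM, and no step to compound 4 can be read. The compounds shown leave open whether benzyl and 4-methyl-3-nitrophenyl on a sulfonyl sulfur differ at all in this assay.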